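Chain homologues of the carbamate series in a growth assay

This account rests on a few compounds, and the source may have more. Where it says the series, first, only, none or still open, it means among the compounds named here.

Measured so far:
compound 1 `CCOC(=O)N1CCN(/[N+]([O-])=N/Oc2cc(O/N=[N+](\[O-])N(C)C)c([N+](=O)[O-])cc2[N+](=O)[O-])CC1` 2000 nM
compound 2 `CCCOC(=O)N1CCN(/[N+]([O-])=N/Oc2cc(O/N=[N+](\[O-])N(C)C)c([N+](=O)[O-])cc2[N+](=O)[O-])CC1` 3900 nM

In a functional assay on HL-60 cells (Homo sapiens) for antiproliferative activity, read by MTT assay, with a stated time of 72 h (a higher number here means a weaker inhibitor of growth, a lower number a stronger inhibitor of growth), compound 1 gives 2000 nM and compound 2 gives 3900 nM; the two numbers sit within the scatter of one another, so compound 2 cannot be set apart from compound 1 on these data. The step of a 2.0-fold higher number from compound 1 to compound 2 (0.29 log units; within the scatter) is the only measured one and it is within the scatter.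

Compound 3 `CCCCOC(=O)N1CCN(/[N+]([O-])=N/Oc2cc(O/N=[N+](\[O-])N(C)C)c([N+](=O)[O-])cc2[N+](=O)[O-])CC1` is not yet measured. It differs from compound 2 by methyl in place of hydrogen on a saturated chain carbon, three bonds along the chain from an oxygen next to a carbonyl group. Among the measured compounds shown here, the only step that bears on it, a 2.0-fold higher number from compound 1 to compound 2 (0.29 log units; within the scatter), was within the scatter, so nothing beyond the scatter is expected in this assay for this further extension; if anything the direction seen before is followed loosely.

Compound 3 is estimated to give 5000 nM in this assay, with a range from 2000 nM to 13000 nM, an expected step of a 1.3-fold higher number from compound 2 to compound 3 (0.11 log units; within the scatter).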

Compound 3, concentration for total growth inhibition: 2700 nM
The estimate for compound 3 lay 1.9-fold (0.27 log units) above the measured number; measured number inside the range.
By their numbers in this assay, from the lowest: compounds 1, 3 and 2 (each within the scatter of the next).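

In this assay, adding methyl three bonds along the chain from the oxygen gives a 1.4-fold lower number from compound 2 to compound 3 (0.16 log units; within the scatter), opposite in sign to the earlier 2.0-fold higher number from compound 1 to compound 2 (0.29 log units; within the scatter), so the first step does not set a direction that holds along the chain. Taken end to end, the ethyl to butyl extension gives a 1.4-fold higher number from compound 1 to compound 3 (0.13 log units; within the scatter), which means that even the larger change at this position stays within the scatter and no chain-length trend can be claimed across compound 1, compound 2 and compound 3. Nothing measured here offers an account of these numbers.

On these data alone, whether a longer chain such as octyl, a branched chain such as isopropyl or a benzyl group would leave the scatter remains open. Also open, as far as these compounds go, is how an amide in place of the carbamate would read.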